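The source may hold more compounds than are shown below. What is called first, only, known or untested is meant among the compounds shown, and "the series" means these compounds.

Three compounds have been measured in a physicochemical assay for acid dissociation:

Compound 1 `COc1ccc(F)cc1CNCCCNc1ccnc2cc(Cc3ccc(C#N)cc3)ccc12` gives 9.47
Compound 2 `COc1ccc(F)cc1CNCCCNc1ccnc2cc(Oc3cccc(N(C)C)c3)ccc12` gives 9.28
Compound 3 `COc1ccc(F)cc1CNCCCNc1ccnc2cc(Oc3ccccc3)ccc12` gives 9.28

All three share the same core and differ only in the group carried on one aromatic carbon of that core. Compound 3 stands close to both others: a number 0.19 log units lower from compound 1 to compound 3 (within the scatter), and no change at the digits printed from compound 2 to compound 3 (within the scatter). Swapping a 4-cyanobenzyl group for a phenoxy group, or removing a dimethylamino group from the phenoxy ring, thus left the number essentially unchanged.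

Compound 4 `COc1ccc(F)cc1CNCCCNc1ccnc2cc(Oc3ccccc3OC)ccc12` is the next step from compound 3. The change is methoxy in place of hydrogen on an aromatic carbon. The two measured steps that bear on this, a number 0.19 log units lower from compound 1 to compound 2 (within the scatter) and no change at the digits printed from compound 2 to compound 3 (within the scatter), show that even larger alterations at this end of the molecule stayed within the scatter. A change of methoxy for hydrogen on the phenoxy ring is therefore expected to give no change at the digits printed from compound 3 to compound 4 (within the scatter), that is, no step beyond the scatter. Compound 4 is expected to give about 9.28 in this assay, with a likely range from 8.95 to 9.6.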

Compound 4, acid dissociation constant: 9.28
Compound 4: middle estimate and measured number agree at the digits printed; the measured number falls inside the stated range.
By their numbers in this assay, from the lowest: compounds 2, 3, 4 and 1 (each within the scatter of the next).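

In this assay, a methoxy group on the phenoxy ring, ortho to a large group, gives no change at the digits printed from compound 3 to compound 4 (within the scatter) and so stays within the scatter, which extends the flat picture to a substituent placed on the ring at this spot. Against the other two compounds the reading is the same: the step is no change at the digits printed from compound 2 to compound 4 (within the scatter) and a number 0.19 log units lower from compound 1 to compound 4 (within the scatter), so 2-methoxyphenoxy sits with 3-(dimethylamino)phenoxy, phenoxy and 4-cyanobenzyl as groups at this carbon with no step beyond the scatter. No supporting measurement is available to explain this result.

The compounds shown leave open whether a carboxylic acid on the phenoxy ring, or a longer chain in place of the phenoxy group, would give a step beyond the scatter. They also leave open what a chloro group elsewhere on the shared core would do to this number.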